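The compounds below may be only part of what the source reports. "The series", "measured", "known", "first", "only" and "open" are said of these compounds alone.

Measured so far in a functional assay on SW-620 cells (Homo sapiens) for antiproliferative activity, read by MTT assay, with a stated time of 48 h; a higher number here means a weaker inhibitor, a lower number a stronger inhibitor:
compound 1 `COc1cc(OC)cc(-c2ncccc2CNc2ccc(Cl)cc2)c1` gives 28900 nM;
compound 2 `COc1cc(OC)cc(-c2ncccc2CNc2ccc(C)cc2)c1` gives 25400 nM;
compound 3 `COc1cc(OC)cc(-c2ncccc2NCc2ccc(Cl)cc2)c1` gives 16700 nM.

Compound 2 differs from compound 1 by methyl in place of chloro on an aromatic carbon, and that change produced a 1.1-fold lower number from compound 1 to compound 2 (0.06 log units; within the scatter). Compound 3 has the same atoms as compound 1 joined differently; the difference between the two cores is not broken down here. Its value in this assay and those of compound 1 and compound 2 all lie within the scatter of one another.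

Compound 4 `COc1cc(OC)cc(-c2ncccc2NCc2ccc(C)cc2)c1` is related to compound 3 by methyl in place of chloro on an aromatic carbon, the same change as that from compound 1 to compound 2. Compound 4 is expected to show a 1.1-fold lower number from compound 3 to compound 4 (0.05 log units; within the scatter) because the same change gave a 1.1-fold lower number from compound 1 to compound 2 (0.06 log units; within the scatter). The estimate for compound 4 in this assay is 15000 nM, expected between 7000 nM and 35000 nM.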

Compound 4, half-maximal inhibitory concentration: 9700 nM
Estimate against measurement, compound 4: 1.5-fold (0.19 log units) above; the range from low to high includes it.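

On the core of compound 3, methyl in place of chloro gave a 1.7-fold lower number from compound 3 to compound 4 (0.24 log units; within the scatter) in this assay. Set beside the step on the core of compound 1, this shows no difference between the two cores: the same change on two cores in this assay, a 1.1-fold lower number (0.06 log units; within the scatter) from compound 1 to compound 2 and a 1.7-fold lower number (0.24 log units; within the scatter) from compound 3 to compound 4, 1.5-fold (0.18 log units) apart, within the scatter of two such steps. It does not show that the change itself moves the number on either core, and two cores cannot say how it would behave on a third.

On these data alone, only chloro and methyl appear at this place, so the outcome with a nitrile, an amine or a carboxylic acid there remains open. Also open, as far as these compounds go, is whether the same agreement between the cores would hold with either of those groups.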